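Propanoyl on the amino nitrogen of compound 2

The compounds below may be only part of what the source reports. "The series", "measured", "known", "first", "only" and "open" are said of these compounds alone.

Three closely related compounds have been measured in a toxicity assay on Huh-7.5 cells (Homo sapiens) for inhibition, read by MTT assay, with a stated time of 96 h; on this read-out higher numbers stand for lower toxicity in this test and lower numbers for higher toxicity in this test. Compound 1 `CN1CCN(Cc2ccc(NC(=O)c3ccc(OCCCCl)c(Cl)c3)cc2C(F)(F)F)CC1` gives 4100 nM, compound 2 `CN1CCN(Cc2ccc(NC(=O)c3ccc(OCCCCl)c(N)c3)cc2C(F)(F)F)CC1` gives 12900 nM and compound 3 `CN1CCN(Cc2ccc(NC(=O)c3ccc(OCCCCCl)c([N+](=O)[O-])c3)cc2C(F)(F)F)CC1` gives 3740 nM. Compound 2 thus has the highest number of the three, clearly separated from both others.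

Compound 4 `CCC(=O)Nc1cc(C(=O)Nc2ccc(CN3CCN(C)CC3)c(C(F)(F)F)c2)ccc1OCCCCl` departs from compound 2 by one change, propanoyl in place of hydrogen on a nitrogen on an aromatic ring, which turns amino into propanoylamino.

For the measured compounds named here, only one measured step bears on this change. It is a 3.1-fold higher number from compound 1 to compound 2 (0.50 log units; beyond the scatter), a modest rise that came with amino in place of chloro on an aromatic carbon, and that amino group is the one now altered. Going by the values given here, no measured compound carries propanoyl, so this evidence is indirect. Compound 4 no longer has the amino group, so a partial return towards compound 1 at 4100 nM is expected, smaller than the rise seen in a 3.1-fold higher number from compound 1 to compound 2 (0.50 log units; beyond the scatter). The expected change is a modest fall in this assay, estimated as a 2.2-fold lower number from compound 2 to compound 4 (0.33 log units; beyond the scatter). For compound 4 the estimated half-maximal cytotoxic concentration is 6000 nM, with an expected range of 2500 nM to 14000 nM.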

Compound 4, half-maximal cytotoxic concentration: 7870 nM
For compound 4 the middle estimate is 1.3-fold (0.12 log units) below the measured one; low and high end bracket the measured number.
By their numbers in this assay, from the lowest: compounds 3, 1, 4 and 2 (each within the scatter of the next, the first and the last beyond it).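

In this assay, propanoyl in place of hydrogen on the nitrogen leaves a difference that the test cannot separate from scatter (a 1.6-fold lower number from compound 2 to compound 4 (0.21 log units; within the scatter)), so this nitrogen accepts the whole propanoyl group without a measurable shift on this read-out. Compound 4 also cannot be told apart from the chloro compound (a 1.9-fold higher number from compound 1 to compound 4 (0.28 log units; within the scatter)), although amino in place of chloro at the same aromatic carbon had given a step beyond the scatter (a 3.1-fold higher number from compound 1 to compound 2 (0.50 log units; beyond the scatter)), so propanoylamino sits within the scatter of both groups and the result does not place it nearer to either. Nothing available here accounts for this outcome.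

The compounds shown leave open whether a smaller acyl group such as acetyl, a longer one such as butanoyl, or a methyl group on this nitrogen would give a step beyond the scatter. They also leave open how the group on this aromatic carbon acts together with a longer chain on the oxygen, since compound 3 differs from the others in more than one place.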